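Replacing chloro with amino: what compound 3 may do

The source may report more compounds than this note shows. Statements on the series, on what has been measured and on what is new or still open speak of the compounds shown alone.

Values in a functional assay on MCF7 cells (Homo sapiens) for antiproliferative activity, read by MTT assay, with a stated time of 72 h; on this read-out lower numbers stand for stronger inhibition and higher numbers for weaker inhibition:
- compound 1 `COc1cc(-n2cnc3ccc(-c4ccccc4Cl)cc32)cc(OC)c1OC`: > 10000 nM
- compound 2 `COc1cc(-n2cnc3ccc(-c4cccc(Cl)c4)cc32)cc(OC)c1OC`: 3120 nM

Among the compounds with values here, compound 2 holds the only true number so far. The entry for compound 1 is a limit, not a number. Compound 3 `COc1cc(-n2cnc3ccc(-c4cccc(N)c4)cc32)cc(OC)c1OC` is not yet measured and differs from compound 2 thus: amino in place of chloro on an aromatic carbon. Within the data shown here, the one measured step, an at least 3.2-fold lower number from compound 1 to compound 2 (0.50 log units; beyond the scatter), moves a chlorine and exchanges no group, so it offers little guidance here. No step beyond the scatter is therefore expected in this assay. The expected size is a 1.2-fold lower number from compound 2 to compound 3 (0.10 log units; within the scatter). The estimate for compound 3 is 2500 nM, with an expected range of 500 nM to 10000 nM.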

Compound 3, half-maximal inhibitory concentration: 180 nM
The estimate for compound 3 lay 14-fold (1.14 log units) above the measured number; measured number below the stated range.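

In this assay, the group on this ring carbon proves to matter far more than moving a chlorine had suggested: amino in place of chloro gives a 17-fold lower number from compound 2 to compound 3 (1.24 log units; beyond the scatter). Exchanging one heavy atom here is enough for a large step, and 3-aminophenyl in place of 2-chlorophenyl gives an at least 55-fold lower number from compound 1 to compound 3 (1.74 log units; beyond the scatter). That second step is a minimum, not an exact size: the limit of > 10000 nM in this assay, at which 1 of the 3 values shown sits.

Going by these compounds, whether amino is special remains open, as a hydroxyl or a methylamino group in this place would show. So does whether an amino group elsewhere on this ring would give the same result.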